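Solubility of Pyrazolopyridine Nitriles: A Ring-Fused Analogue

The source may report more compounds than this note shows. Statements on the series, on what has been measured and on what is new or still open speak of the compounds shown alone.

Measured compounds:
Compound 1, `CCc1ccc(-c2nc3c(c(C)nn3-c3ccccc3)c(-c3ccccc3C)c2C#N)cc1`, 6000 nM
Compound 2, `Cc1cccc(-c2nc3c(c(C)nn3-c3ccccc3)c(-c3ccccc3O)c2C#N)c1`, 42000 nM

For the measured compounds named here, in a physicochemical assay for solubility, read by spectrophotometry, in phosphate buffer, with a stated time of 18 h, at pH 7.4 (a lower number here means a less soluble compound, a higher number a more soluble compound), compound 2 gives 42000 nM and stands highest of the two numbers known so far. Going by the values given here, its nearest neighbour is compound 1, which in this assay gives 6000 nM, a gap that lies beyond the usual scatter; the two compounds differ in more than one place, so no single step can be drawn between them.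

Compound 3, `Cc1nn(-c2ccccc2)c2nc(-c3ccc4c(c3)CCCC4)c(C#N)c(-c3ccccc3O)c12`, has not yet been measured. It differs from compound 2 in one place: 1,2,3,4-tetrahydronaphthalen-6-yl in place of 3-methylphenyl on an aromatic carbon. A larger group enters where a smaller one left, with no change in donors, acceptors or charge.

Among the compounds with values here, with no measured step of this kind available, the size of the change is estimated rather than known. Compound 3 is expected to show a modest drop, with the step of a 2.8-fold lower number from compound 2 to compound 3 (0.45 log units; beyond the scatter), pointing to lower solubility. Compound 3 is therefore estimated at 15000 nM, in the range 5000 nM to 40000 nM.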

Compound 3, solubility: 13000 nM
Compound 3: the middle estimate sits 1.2-fold (0.06 log units) above what was measured, and the stated range covers the measured number.
By their numbers in this assay, from the lowest: compound 1; then compound 3; then compound 2.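

In this assay, for the compounds shown here, the exchange of 3-methylphenyl for 1,2,3,4-tetrahydronaphthalen-6-yl, on the aromatic carbon next to the ring nitrogen, gives a 3.2-fold lower number from compound 2 to compound 3 (0.51 log units; beyond the scatter) and so provides the first single-place step. It shows that the number responds to the group at this position even when the exchange adds only carbon, in one six-membered non-aromatic ring, and leaves the counts of hydrogen-bond donors and acceptors and the net charge unchanged. No measurement shown here bears on why the number falls.

Going by these compounds, whether an amine or a carboxylic acid carried on the aryl group at this position would raise or lower the number remains open. So does whether the same exchange would give a step of similar size with another group in place of 2-hydroxyphenyl.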